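Chloro in Place of Trifluoromethyl: What Compound 3 May Give

The source may report more compounds than this note shows. Statements on the series, on what has been measured and on what is new or still open speak of the compounds shown alone.

Compound 2 `CC(C(=O)N1CCN(c2cccc(C(F)(F)F)c2)CC1)N1C(=O)CCC1=O` stands highest of the two measured compounds. In a functional assay on the whole organism (strain Swiss) with Mus musculus as the target, in the maximal electroshock model, with a stated time of 1 h, at a dose of 300 mg/kg by the intraperitoneal route (a higher number here means a stronger effect of the compound at the dose given, a lower number a weaker effect), compound 2 gives 100%, while compound 1 `CC(C(=O)N1CCN(c2ccc(F)cc2)CC1)N1C(=O)CCC1=O` gives 25%, a gap well beyond the usual scatter. Compound 3 `CC(C(=O)N1CCN(c2cccc(Cl)c2)CC1)N1C(=O)CCC1=O` keeps the shared core and differs from compound 2 in a single place: chloro in place of trifluoromethyl on an aromatic carbon. Within the data shown here, no measured pair shows how this exchange plays out, so the expectation rests on compound 2 alone. The expected step, a number 20 percentage points lower from compound 2 to compound 3 (beyond the scatter), is a modest fall or none beyond the scatter. For compound 3 the estimate is 80%, within a range from 40% to 100%.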

Compound 3, a percentage reported as activity, at one dose (the size of the read-out at that dose, not a potency): 75%
For compound 3 the middle estimate is 5 percentage points above the measured one; the measured number falls inside the stated range.
By their numbers in this assay, from the lowest: compound 1; then compound 3; then compound 2.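

In this assay, chloro in place of trifluoromethyl on the aromatic carbon gives a number 25 percentage points lower from compound 2 to compound 3 (beyond the scatter), so activity at this position does not depend entirely on trifluoromethyl, though the exchange has a real cost. The step to 3-chlorophenyl in place of 4-fluorophenyl gives a number 50 percentage points higher from compound 1 to compound 3 (beyond the scatter), but it changes both the halogen and its place on the ring, so their separate contributions cannot be told apart. No measurement available here explains either step. As far as these compounds go, how a methoxy group or an amine would fare at this position remains open.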